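The source may report more compounds than this note shows. Statements on the series, on what has been measured and on what is new or still open speak of the compounds shown alone.

Working notes on the series in an ADME assay on MT4 cells (Homo sapiens) for cytotoxicity, read by MTT assay, with a stated time of 4 days; on this read-out higher numbers stand for lower toxicity in this test and lower numbers for higher toxicity in this test. Compound 1 (`CC(=O)Nc1ccc2oc(-c3ccc(F)cc3)cc(=O)c2c1`) gives 203000 nM, compound 2 (`COc1c(-c2ccccc2)oc2ccc(NC(C)=O)cc2c1=O`) gives 200000 nM, and compound 3 (`COc1ccc(-c2oc3ccc(NC(C)=O)cc3c(=O)c2OC)cc1`) gives 369000 nM. Compound 3 lies within the scatter of both others, so the numbers shown do not separate these three compounds.

Compound 4 (`COc1c(-c2ccc(F)cc2)oc2ccc(NC(C)=O)cc2c1=O`) is not yet measured. It differs from compound 3 by fluoro in place of methoxy on an aromatic carbon, read further out as 4-methoxyphenyl to 4-fluorophenyl. For the measured compounds named here, no measured step makes this exact replacement. The nearest one is a 1.8-fold higher number from compound 2 to compound 3 (0.27 log units; within the scatter), where methoxy replaces hydrogen. Compound 1 also carries 4-fluorophenyl and sits at 203000 nM, which supports expecting a value in the same region.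

No change beyond the scatter is therefore expected in this assay. The expected change is a 1.5-fold lower number from compound 3 to compound 4 (0.17 log units; within the scatter). The estimated value for compound 4 is 250000 nM, with an expected range of 120000 nM to 500000 nM.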

Compound 4, half-maximal cytotoxic concentration: 317000 nM
For compound 4 the middle estimate is 1.3-fold (0.10 log units) below the measured one; the range from low to high includes it.
By their numbers in this assay, from the lowest: compounds 2, 1, 4 and 3 (each within the scatter of the next).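

In this assay, the position on the aromatic carbon para to a large group now carries hydrogen, methoxy and fluoro, and the numbers do not separate them: fluoro in place of methoxy stays within the scatter (a 1.2-fold lower number from compound 3 to compound 4 (0.07 log units; within the scatter)), as does fluoro in place of hydrogen (a 1.6-fold higher number from compound 2 to compound 4 (0.20 log units; within the scatter)). Methoxy in place of hydrogen can also be read a second time, on a different core, again within the scatter (a 1.6-fold higher number from compound 1 to compound 4 (0.19 log units; within the scatter)). The two readings agree: the same change on two cores in this assay, a 1.8-fold higher number (0.27 log units; within the scatter) from compound 2 to compound 3 and a 1.6-fold higher number (0.19 log units; within the scatter) from compound 1 to compound 4, 1.2-fold (0.07 log units) apart, within the scatter of two such steps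

The compounds shown leave open whether any group at this carbon moves the number beyond the scatter. An amine, a carboxylic acid or a longer chain than methoxy there would test this, and the same groups on the shared core would show whether the two cores continue to agree.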